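Sulfonyl aryl exchange in the shared core: working notes

The source may hold more compounds than are shown below. What is called first, only, known or untested is meant among the compounds shown, and "the series" means these compounds.

Measured so far in a functional assay on HepG2 cells (Homo sapiens) for antiproliferative activity, with a stated time of 72 h; on this read-out higher numbers stand for an effect only at larger amounts of compound and lower numbers for an effect already at smaller amounts:
compound 1 `COc1ccc(-c2cc(=O)c3c(OC)cc(OC)cc3n2S(=O)(=O)c2ccc([N+](=O)[O-])cc2)cc1`: > 29300 nM.
compound 2 `COc1ccc(-c2cc(=O)c3c(OC)cc(OC)cc3n2S(=O)(=O)c2ccc(Cl)cc2)cc1`: > 34400 nM.

For compound 1 the value > 29300 nM is a limit of the assay, not a number. For compound 2 the value > 34400 nM is likewise a limit. The step that the two limits leave unreadable from compound 1 to compound 2 is therefore unreadable in size, since both ends sit at the limit of > 29300 nM in this assay, at which 1 of the 2 values shown sits, and (the limit of > 34400 nM in this assay, at which 1 of the 2 values shown sits). Compound 2 thus stands at a limit, with no measured number to anchor it.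

Compound 3 `COc1ccc(-c2cc(=O)c3c(OC)cc(OC)cc3n2S(=O)(=O)c2ccc(Br)s2)cc1` differs from compound 2 by 5-bromothiophen-2-yl in place of 4-chlorophenyl on a sulfonyl sulfur. No measured step bears on this change; the only step shown concerns the substituent on the sulfonyl aryl ring and is itself unreadable. For compound 3 the expectation is accordingly a value near the limit again, estimated at 30000 nM (range 8000 nM to 60000 nM), with the expected step of an at least 1.1-fold lower number from compound 2 to compound 3 (0.05 log units; that floor lies within the scatter) not beyond the scatter, and a high chance that the expected outcome is again only a limit.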

Compound 3, half-maximal effective concentration: > 48200 nM
Compound 3: only a limit was reported (the forecaster's own chance of this, stated with the estimate: 75%); at least 1.6-fold (0.20 log units) between middle value and limit.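

In this assay compound 3 gives > 48200 nM, which is a limit and not a number. Going by these compounds alone, with compound 1, compound 2 and compound 3 all standing at limits, no step among them can be read. The compounds shown leave open whether any group on the sulfonyl sulfur of the shared core gives a measurable value in this assay.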